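This account rests on a few compounds, and the source may have more. Where it says the series, first, only, none or still open, it means among the compounds named here.

In a functional assay on RAW264.7 cells (Mus musculus) for inhibition, read by Griess assay, with a stated time of 20 h (a lower number here means a stronger inhibitor, a higher number a weaker inhibitor), compound 2 `O=C(c1cc(-n2cc(-c3ccccc3)nn2)ccc1O)N1CCCCC1` gives > 20000 nM as a limit of the assay, not a number. Compound 3 `O=C(c1cc(-n2cc(-c3cc(F)cc(F)c3)nn2)ccc1O)N1CCCCC1` gives > 20000 nM as a limit too. Compound 1 `CCCCCc1ccc(-c2cn(-c3ccc(O)c(C(=O)NCCC)c3)nn2)cc1` gives > 20000 nM as a limit as well. For the measured compounds named here, the picture in this assay so far is therefore the limit of > 20000 nM in this assay, at which 3 of the 3 values shown sit, and no true number has been read for any compound.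

Compound 4 `CCCCCc1ccc(-c2cn(-c3ccc(O)c(C(=O)N4CCCCC4)c3)nn2)cc1` differs from compound 2 in one place: pentyl in place of hydrogen on an aromatic carbon and nothing else changes. Going by the values given here, the one measured step between close neighbours is a step that the two limits leave unreadable from compound 2 to compound 3 and it offers no size to carry over. The pentyl group itself already appears in compound 1, which still reached only the limit given above. With no readable step to go on, no shift in either direction can be argued from these data. The expected step is a number no higher from compound 2 to compound 4 (the limit leaves the size open) and nothing beyond the scatter is expected. For compound 4 the estimated value is 20000 nM with an expected range from 8000 nM to 40000 nM and a good chance that the assay again reports only a limit.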

Compound 4, half-maximal inhibitory concentration: > 20000 nM
Compound 4: no number, only a limit (the forecaster's own chance of this, stated with the estimate: 70%); the middle value lies on the limit itself.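

Neither the step from compound 2 to compound 4 nor the step from compound 1 to compound 4 can be read, because both compounds of each pair give only limits: the limit of > 20000 nM in this assay, at which 4 of the 4 values shown sit.

The compounds shown leave open whether any of these changes alters true inhibitory strength in this assay.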